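The compounds below may be only part of what the source reports. "The series", "measured", "known", "first", "only" and "open" are said of these compounds alone.

Measured compounds:
- compound 1 `COC(=O)[C@@]1(C)CCC=C2[C@@H]1CC[C@@H](C)[C@]2(C)Cc1c(C)[nH]c2ccc(Br)cc12`, 11000 nM in a functional assay on HeLa cells (Homo sapiens) for inhibition, read by sulforhodamine B assay, with a stated time of 48 h; a higher number here means a weaker inhibitor of growth, a lower number a stronger inhibitor of growth
- compound 2 `COC(=O)[C@@]1(C)CCC=C2[C@@H]1CC[C@@H](C)[C@]2(C)Cc1c(C)[nH]c2ccc(Cl)cc12`, 12000 nM in this assay

For the measured compounds named here, compound 2 has the highest of the two numbers so far in this assay, but the nearest point is compound 1, and the step of a 1.1-fold higher number from compound 1 to compound 2 (0.04 log units; within the scatter) is within the scatter, so the two halogen analogues are not distinguished by these data.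

The next step goes from compound 2 to compound 3 `COC(=O)[C@@]1(C)CCC=C2[C@@H]1CC[C@@H](C)[C@]2(C)Cc1c(C)[nH]c2ccc(OC)cc12`, not yet measured. The change is methoxy in place of chloro on an aromatic carbon. Going by the values given here, no measured pair bears on a methoxy group at this position; the only step known, a 1.1-fold higher number from compound 1 to compound 2 (0.04 log units; within the scatter), swaps one halogen for another and shows that this position tolerated that exchange without a change beyond the scatter. Whether a methoxy group behaves the same way cannot be read from the two halogen compounds. In the absence of any relevant step, the expectation is a number close to that of compound 2, with a widened range to allow for the untested group. For compound 3 the estimate in this assay is 13000 nM, range 5000 nM to 35000 nM, which means an expected step of a 1.1-fold higher number from compound 2 to compound 3 (0.03 log units; within the scatter).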

Compound 3, concentration for 50% growth inhibition: 12000 nM
Compound 3: middle estimate off by 1.1-fold (0.03 log units), on the high side, within the range that was stated.
By their numbers in this assay, from the lowest: compounds 1, 2 and 3 (each within the scatter of the next).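

In this assay the aromatic carbon that held a halogen in compound 1 and compound 2 also takes a methoxy group, which brings two heavy atoms in place of one and one hydrogen-bond acceptor where the halogens brought none. The exchange leaves the read-out flat, with no change at the digits printed from compound 2 to compound 3 (within the scatter) and a 1.1-fold higher number from compound 1 to compound 3 (0.04 log units; within the scatter), so the earlier finding, limited to one halogen for another, now extends to a group that is not a halogen. Bromo, chloro and methoxy at this place are not told apart by this assay, and no supporting data explain that result.

The three compounds leave open whether an amine, a carboxylic acid, a longer chain such as butoxy, or plain hydrogen at this place would give a step beyond the scatter. Also open, going by these compounds, is whether the growth inhibition responds to changes elsewhere on the shared core, for example a carboxylic acid in place of the methyl ester or a different group on the indole nitrogen.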